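The compounds below may be only part of what the source reports. "The series", "measured", "known", "first", "only" and "open" are said of these compounds alone.

Compound 1 `Nc1nc(NCCNc2ncc(-c3ncc[nH]3)c(-c3ccccc3Br)n2)ccc1[N+](=O)[O-]`: in an ADME assay on microsomes from liver (Rattus norvegicus) for metabolic stability (on this read-out higher numbers stand for a longer-lived compound and lower numbers for a shorter-lived compound), compound 1 gives > 0.5 h, which is a limit of the assay.
Compound 2 `Nc1nc(NCCNc2ncc(-c3ncc[nH]3)c(-c3cc(F)ccc3Cl)n2)ccc1[N+](=O)[O-]`: in this assay compound 2 gives > 0.5 h, again a limit.
Compound 3 `Cc1ccc(-c2nc(NCCNc3ccc([N+](=O)[O-])c(N)n3)ncc2-c2ncc[nH]2)c(Br)c1`: in this assay compound 3 gives > 0.5 h, again a limit.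

Compound 1 therefore stands where every measured compound stands, at the limit of > 0.5 h in this assay, at which 3 of the 3 values shown sit; no number places it apart from the others. The unmeasured compound 4 `Cc1cc(Cl)ccc1-c1nc(NCCNc2ccc([N+](=O)[O-])c(N)n2)ncc1-c1ncc[nH]1` differs from compound 1 as follows: 4-chloro-2-methylphenyl in place of 2-bromophenyl on an aromatic carbon.

Two measured steps start from compound 1 and bear on this change. The step that the two limits leave unreadable from compound 1 to compound 2 exchanges one halogenated phenyl for another, and the step that the two limits leave unreadable from compound 1 to compound 3 adds a methyl to the ring; neither can be read, because both end values sit at the limit of > 0.5 h in this assay, at which 3 of the 3 values shown sit. The third step, a step that the two limits leave unreadable from compound 2 to compound 3, is unreadable for the same reason.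

With every exchange on this ring so far leaving the read-out at the limit, the observer expects compound 4 to behave alike: the step that the limit leaves unreadable from compound 1 to compound 4 is expected to be no more than scatter, with the value most likely again reported as a limit. The estimate for compound 4 in this assay is 1 h, within 0.5 h to 3 h.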

Compound 4, half-life: > 0.5 h
Compound 4: no number, only a limit (the forecaster's own chance of this, stated with the estimate: 80%); the middle value is on the limit's open side.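

In this assay compound 4 gives > 0.5 h, which is a limit, so no step from compound 1, compound 2 or compound 3 to compound 4 can be read: the limit of > 0.5 h in this assay, at which 4 of the 4 values shown sit.

The compounds shown leave open how long any of the four actually lasts, and whether exchanging these substituted phenyl groups changes the read-out at all.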